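A few compounds are considered here, and "the series" means these few. Any claim that something is new, unique, unknown or untested is made for them only; others in the source may bear on it.

Compound 1 `Cc1nc(-c2ccccc2)c(C(=O)N2CCN(c3cccc(Cl)c3Cl)CC2)o1` and compound 2 `Cc1nc(-c2ccccc2)c(C(=O)N2CCN(c3ccc(C(F)(F)F)cc3)CC2)o1` share one core and differ only in the group on an amine nitrogen in a ring. In a functional assay on HL-60 cells (Homo sapiens) for inhibition, read by MTT assay, with a stated time of 72 h (a higher number here means a weaker inhibitor, a lower number a stronger inhibitor), compound 1 gives 133 nM. For compound 2 the same measurement returns only a limit, > 1000 nM, so its true number is not known. The step of an at least 7.5-fold higher number from compound 1 to compound 2 (0.87 log units; beyond the scatter) thus shows at least a loss, with its full size open because compound 2 sits at the limit of > 1000 nM in this assay, at which 1 of the 2 values shown sits. Compound 3 `COc1cc(OC)cc(N2CCN(C(=O)c3oc(C)nc3-c3ccccc3)CC2)c1` differs from compound 2 in one place: 3,5-dimethoxyphenyl in place of 4-(trifluoromethyl)phenyl on an amine nitrogen in a ring. Within the data shown here, no measured step covers 3,5-dimethoxyphenyl at this position, and the one step that bears on it, an at least 7.5-fold higher number from compound 1 to compound 2 (0.87 log units; beyond the scatter), concerns a group that compound 3 does not carry. The expected step that the limit leaves unreadable from compound 2 to compound 3 is therefore uncertain in direction, and a limit may again be reported. Compound 3 is estimated at 2000 nM, within 300 nM to 10000 nM.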

Compound 3, half-maximal inhibitory concentration: 19.2 nM
Estimate against measurement, compound 3: 100-fold (2.02 log units) above; the whole stated range lies above it.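

In this assay, among these compounds, the earlier pair showed only that a change at this position, the group on an amine nitrogen in a ring, could weaken inhibition. Compound 3 shows that the same position can also strengthen it: 3,5-dimethoxyphenyl in place of 4-(trifluoromethyl)phenyl gives an at least 52-fold lower number from compound 2 to compound 3 (1.71 log units; beyond the scatter), and in place of 2,3-dichlorophenyl it gives a 6.9-fold lower number from compound 1 to compound 3 (0.84 log units; beyond the scatter), which makes compound 3 the strongest inhibitor of the three. The full size of the first of these steps stays open because compound 2 has only a limit and not a number: the limit of > 1000 nM in this assay, at which 1 of the 3 values shown sits.

The compounds shown do not tell whether both methoxy groups are needed, since a phenyl ring with a single methoxy group is not among them. Nor do they tell whether hydroxy groups in place of the methoxy groups would give a similar number.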